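Iodo for methyl on compound 3: cytotoxicity expectation

The compounds below may be only part of what the source reports. "The series", "measured", "known", "first", "only" and "open" are said of these compounds alone.

Compound 1, `CCc1ccc(-c2nc3c(c(C)nn3-c3ccccc3)c(-c3ccccc3I)c2C#N)cc1`, in an ADME assay on BJ cells (Homo sapiens) for cytotoxicity, with a stated time of 72 h (on this read-out higher numbers stand for an effect only at larger amounts of compound and lower numbers for an effect already at smaller amounts), gives a limit of the assay, > 20000 nM.
Compound 2, `CCc1ccc(-c2nc3c(c(C)nn3-c3ccccc3)c(-c3ccccc3C(F)(F)F)c2C#N)cc1`, in this assay gives a limit of the assay, > 20000 nM.
Compound 3, `Cc1ccc(-c2nc3c(c(C)nn3-c3ccccc3)c(-c3ccccc3O)c2C#N)cc1`, in this assay gives 22200 nM.

Compound 3 is the only one of the three with a number; the other two values are limits, as the limit of > 20000 nM in this assay, at which 2 of the 3 values shown sit, shows. Compound 4, `Cc1nn(-c2ccccc2)c2nc(-c3ccc(I)cc3)c(C#N)c(-c3ccccc3O)c12`, is not yet measured in this assay. It differs from compound 3 in one place: iodo in place of methyl on an aromatic carbon.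

For the measured compounds named here, the only measured step is a step that the two limits leave unreadable from compound 1 to compound 2, which concerns trifluoromethyl in place of iodo at another place on the shared core and which the two limits leave unreadable. Going by the values given here, no measured step addresses iodo in place of methyl, and the limits at which compound 1 and compound 2 sit carry no readable size. Compound 3 alone anchors the expectation, with its 22200 nM. No step beyond the scatter is expected for compound 4: a 1.0-fold lower number from compound 3 to compound 4 (0.00 log units; within the scatter). Compound 4 is estimated at 22000 nM in this assay, within 11000 nM to 44000 nM.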

Compound 4, half-maximal effective concentration: 19000 nM
Beside the measured number, compound 4's estimate is 1.2-fold (0.06 log units) above it, within the range that was stated.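

Iodo in place of methyl on an aromatic carbon gives a 1.2-fold lower number from compound 3 to compound 4 (0.07 log units; within the scatter) in this assay, the only readable step among the compounds shown. For the compounds shown here, at this place, para to a large group, 4-methylphenyl and 4-iodophenyl therefore read alike within the scatter of the cytotoxicity read-out on this core, a point on which the earlier compounds gave no information. The one earlier step cannot be read, and compound 1 and compound 2 each remain at a limit of the assay: the limit of > 20000 nM in this assay, at which 2 of the 4 values shown sit.

From the compounds shown here alone, how an amine, a carboxylic acid or a longer chain at this same place would read remains open. Going by these compounds, compound 1 and compound 2 differ from compound 4 in more than one place, and the effect of each separate difference is also open.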